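Silyl-ethyl ether in place of a methyl on compound 3

The compounds below may be only part of what the source reports. "The series", "measured", "known", "first", "only" and "open" are said of these compounds alone.

Measured compounds, with their readings in a functional assay on MIA PaCa-2 cells (Homo sapiens) for antiproliferative activity, read by MTT assay, with a stated time of 72 h; a higher number here means a weaker inhibitor, a lower number a stronger inhibitor:
- compound 1 `COc1nc(CC(O)(COCc2ccccc2)COCc2ccccc2)c(C)c(OC)n1` gives 6100 nM.
- compound 2 `COCn1c(CC(O)(COCc2ccccc2)COCc2ccccc2)cc(=O)[nH]c1=O` gives a limit of the assay, > 100000 nM.
- compound 3 `COCn1c(CC(O)(CO)CO)cc(=O)[nH]c1=O` gives a limit of the assay, > 100000 nM.

Compound 3 stands at the edge of what this assay reports: its reading is a limit and not a number, as is the reading of compound 2 (the limit of > 100000 nM in this assay, at which 2 of the 3 values shown sit). Going by the values given here, only compound 1 gives a measured value, and no pair of measured compounds differs in one place, so no measured step is available to guide the next change.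

Compound 4 `C[Si](C)(C)CCOCn1c(CC(O)(CO)CO)cc(=O)[nH]c1=O` differs from compound 3 by a group of 5 heavy atoms (4 carbon, 1 silicon; no ring) in place of a hydrogen atom, on a saturated chain carbon bound to an oxygen on a saturated carbon. Among the compounds with values here, no step tells what a change of this kind does in this assay. With compound 3 at the limit, the expected step from compound 3 to compound 4 is a number no higher from compound 3 to compound 4 (the limit leaves the size open), that is, none beyond the scatter. For compound 4 the estimated value in this assay is 100000 nM, within the range 30000 nM to 300000 nM, and a further limit reading is thought the likelier outcome.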

Compound 4, half-maximal inhibitory concentration: > 100000 nM
Compound 4 was reported as a limit; the forecaster's own chance of this, stated with the estimate: 70%; the middle value lies on the limit itself.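

No step can be read from compound 3 to compound 4 in this assay, since the readings of both compounds are limits of the assay and not numbers: the limit of > 100000 nM in this assay, at which 3 of the 4 values shown sit. The compounds shown leave open what a group of 5 heavy atoms (4 carbon, 1 silicon; no ring) in place of a hydrogen atom does to the reading.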